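From a Hexyl Chain to a Phenyl Ring on the Amide Nitrogen

This account rests on a few compounds, and the source may have more. Where it says the series, first, only, none or still open, it means among the compounds named here.

Three related compounds have been measured. In a functional assay on membranes from Sf9 cells for agonist activity at histamine H2 receptor (Homo sapiens), read by scintillation counting and GTPgammaS binding, with a stated time of 90 min (a higher number here means a larger maximal response, a lower number a smaller maximal response), compound 1 `Cc1ccc(CC(C)CNC(=O)/N=C(\N)NCCCc2sc(N)nc2C)cc1` gives 0.68. Compound 3 `CCCCCCNC(=O)/N=C(\N)NCCCc1sc(N)nc1C`, which carries a hexyl chain on its amide-type nitrogen, gives 0.6 in this assay, the second highest of the three numbers, lying within the scatter of compound 1 and well beyond the scatter of compound 2 `CCCCCCNC(=O)/N=C(\N)NC1CCc2nc(N)sc2C1`, which gives 0.16. Compound 4 `Cc1nc(N)sc1CCCN/C(N)=N/C(=O)Nc1ccccc1` differs from compound 3 by a single change: phenyl in place of hexyl on an amide-type nitrogen. Among the measured compounds shown here, no measured pair shows this exact change, so its effect is open. The step is expected to be modest, most likely a small drop that may stay within the scatter: a number 0.10 lower from compound 3 to compound 4 (within the scatter). Compound 4 is therefore estimated at 0.5, with a range from 0.25 to 0.75.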

Compound 4, intrinsic activity: the largest response reached, as a fraction of the reference agonist's: 0.59
For compound 4 the middle estimate is 0.090 below the measured one; the range from low to high includes it.
By their numbers in this assay, from the lowest: compound 2; then compounds 4, 3 and 1 (each within the scatter of the next).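

In this assay, phenyl in place of hexyl on this amide-type nitrogen gives a number 0.010 lower from compound 3 to compound 4 (within the scatter), so the step stays within the scatter. At this position, then, an aromatic ring and an open chain, each of six carbons, give maximal responses that cannot be told apart. No measurement here bears on why the two groups read alike. Still open, as far as these compounds go, is whether a cyclohexyl ring, an octyl chain or a chlorine on the phenyl ring would leave the response unchanged. Also open, from the compounds shown here alone, is whether the same swap would read alike on the core of compound 2.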